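The source may report more compounds than this note shows. Statements on the series, on what has been measured and on what is new or still open speak of the compounds shown alone.

Of the compounds shown here, three built on one shared core have been measured in an assay on CHO cells for displacement of a labelled ligand from adenosine receptor A1 (Homo sapiens); on this read-out higher numbers stand for weaker inhibition and lower numbers for stronger inhibition. Compound 1 `CNC(=O)c1cnc(NC(=O)NC2CCCCC2)n2nc(-c3ccco3)nc12` gives 8990 nM. Compound 2 `CCOC(=O)c1cnc(N(C)C)n2nc(-c3ccco3)nc12` gives 13400 nM, and compound 3 `CCNc1ncc(C(=O)O)c2nc(-c3ccco3)nn12` gives 11900 nM. On these numbers compound 3 stands second highest of the three, yet its gap to compound 2 and its gap to compound 1 both fall inside the usual scatter of repeated measurements, so the three read as one cluster of weak binders rather than as a ranked series.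

Compound 4 `O=C(O)c1cnc(NCc2ccc(Cl)cc2)n2nc(-c3ccco3)nc12` has not yet been measured. It differs from compound 3 by 4-chlorophenyl in place of methyl on a saturated chain carbon bound to a nitrogen on an aromatic ring. For the measured compounds named here, no step between two measured compounds matches this change, so nothing in the measured set shows how large its effect is. The whole set sits at weak binding throughout. The estimate for compound 4 is a modest move toward stronger binding, a 3.0-fold lower number from compound 3 to compound 4 (0.47 log units; beyond the scatter), carrying wide uncertainty. Compound 4 is therefore expected to give 4000 nM in this assay, within a range from 800 nM to 20000 nM.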

Compound 4, inhibition constant: > 100000 nM
Compound 4 gave a limit, no number; the forecaster's own chance of this, stated with the estimate: 5%; middle value at least 25-fold (1.39 log units) away from the limit.
By their numbers in this assay, from the lowest: compounds 1, 3 and 2 (each within the scatter of the next). At a limit, above all of these: compound 4.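

Before this result the compounds shown offered no measure of this position: compounds 1, 3 and 2 each lay within the scatter of the next, and no step linked two of them. In this assay, going from ethyl to 4-chlorobenzyl gives an at least 8.4-fold higher number from compound 3 to compound 4 (0.92 log units; beyond the scatter), so this position responds to change, and this change moves toward weaker inhibition. Compound 4 reads as a limit and not as a number, so the step gives only a minimum size: the limit of > 100000 nM in this assay, at which 1 of the 4 values shown sits.

The compounds shown leave open whether the chlorine, the phenyl ring or the added length carries this shift, which a plain benzyl or a propyl at the same place could separate. They also leave open how far the step would run beyond this limit.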